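The source may hold more compounds than are shown below. What is called first, only, known or untested is meant among the compounds shown, and "the series" means these compounds.

In a functional assay on MDA-MB-468 cells (Homo sapiens) for cytotoxicity, read by MTT assay, with a stated time of 96 h (on this read-out lower numbers stand for stronger inhibition and higher numbers for weaker inhibition), compound 2 `Cc1ccc(-c2ccc(-c3ccc(C(=N)N)cc3)o2)cc1` gives 3700 nM and compound 1 `CCc1ccc(-c2ccc(-c3ccc(C(=N)N)cc3)o2)cc1` gives 3300 nM, so the two lie within the scatter of each other. Compound 3 `CC(C)(C)c1ccc(-c2ccc(-c3ccc(C(=N)N)cc3)o2)cc1`, not yet measured, carries tert-butyl in place of methyl on an aromatic carbon. Among the measured compounds shown here, the only measured step at this group, a 1.1-fold higher number from compound 1 to compound 2 (0.05 log units; within the scatter), is small, so no change beyond the scatter is expected, although this swap adds more carbon than that step removes and the range stays wide. The expected step is a 1.2-fold lower number from compound 2 to compound 3 (0.09 log units; within the scatter). For compound 3 the estimated value is 3000 nM, with an expected range of 1300 nM to 7000 nM.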

Compound 3, half-maximal inhibitory concentration: 3800 nM
Compound 3: the middle estimate sits 1.3-fold (0.10 log units) below what was measured; low and high end bracket the measured number.
By their numbers in this assay, from the lowest: compounds 1, 2 and 3 (each within the scatter of the next).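

Replacing methyl with tert-butyl (a 1.0-fold higher number from compound 2 to compound 3 (0.01 log units; within the scatter)) or ethyl with tert-butyl (a 1.2-fold higher number from compound 1 to compound 3 (0.06 log units; within the scatter)) in this assay stays within the scatter. The earlier pair showed this only for a one-carbon difference, whereas here a group of 4 carbon replaces a group of 1 carbon on the same aromatic carbon, and the number still does not move beyond the scatter. No measured evidence accounts for this result. The compounds shown are all plain carbon groups, so it remains open whether an amine or a carboxylic acid at this position would give a different number.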